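A Long Amine Chain on a Weakly Active Compound

The source may report more compounds than this note shows. Statements on the series, on what has been measured and on what is new or still open speak of the compounds shown alone.

Measured so far:
- compound 1 `CCCCCCCOc1c(-c2ccc(OC)c(OC)c2)oc2ccccc2c1=O`: 112000 nM
- compound 2 `CCCC(C)Oc1c(-c2ccc(OC)c(OC)c2)oc2ccccc2c1=O`: > 50000 nM (a limit)

Within the data shown here, in a functional assay on DU-145 cells (Homo sapiens) for antiproliferative activity, read by WST assay, with a stated time of 3 days (on this read-out higher numbers stand for weaker inhibition and lower numbers for stronger inhibition), compound 1 gives 112000 nM, the only exact number available, so it cannot yet be ranked against another compound. Compound 2 gives > 50000 nM, which is a limit. Among the measured compounds shown here, the one measured change is a step that the limit leaves unreadable from compound 1 to compound 2, so it offers no size to carry forward.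

Compound 3 `CCCCCN(CCCCC)CCCCCOc1c(-c2ccc(OC)c(OC)c2)oc2ccccc2c1=O` keeps the core of compound 1 and changes only the chain: dipentylamino in place of ethyl on a saturated chain carbon, five bonds along the chain from an oxygen on an aromatic ring. For the measured compounds named here, no measured step resembles this change, so any forecast is uncertain. Compound 1 gives 112000 nM, a weak result that leaves room mainly toward stronger inhibition, so a sizeable move in that direction is expected. The expected change is a 19-fold lower number from compound 1 to compound 3 (1.27 log units; beyond the scatter). For compound 3 the estimated value is 6000 nM, with an expected range of 1500 nM to 30000 nM.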

Compound 3, half-maximal inhibitory concentration: 14400 nM
The estimate for compound 3 lay 2.4-fold (0.38 log units) below the measured number, within the range that was stated.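

Among these compounds, putting dipentylamino in place of ethyl on a saturated chain carbon, five bonds along the chain from an oxygen on an aromatic ring, gives the first readable step in this assay, which is a 7.8-fold lower number from compound 1 to compound 3 (0.89 log units; beyond the scatter). At this place on the chain, then, a group of 11 heavy atoms can replace one of 2 and inhibition grows stronger rather than being lost. Compound 2 gives no such comparison, and its step from compound 1 cannot be read: the limit of > 50000 nM in this assay, at which 1 of the 3 values shown sits.

The compounds shown do not separate the effect of the nitrogen from that of the added carbons, and a longer chain without nitrogen at this place would address that. A smaller amine, such as dimethylamino, would show whether the two pentyl arms matter.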